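A few compounds are considered here, and "the series" means these few. Any claim that something is new, unique, unknown or untested is made for them only; others in the source may bear on it.

Working notes on the naphthylmethyl-piperidine amide series. Within the data shown here, in an assay on isolated protein for binding affinity to melanin-concentrating hormone receptor 1 (Homo sapiens) (on this read-out lower numbers stand for stronger inhibition and higher numbers for weaker inhibition), compound 3 `COc1cc(C(=O)NC2CCN(Cc3ccc4ccccc4c3)CC2)ccc1F` gives 13 nM, the lowest of the three numbers so far. Compound 2 `O=C(NC1CCN(Cc2ccc3ccccc3c2)CC1)c1ccc(F)c(F)c1` gives 18 nM, within the scatter of compound 3, while compound 1 `COc1cc(OC)cc(C(=O)NC2CCN(Cc3ccc4ccccc4c3)CC2)c1` gives 27 nM; the step of a 2.1-fold lower number from compound 1 to compound 3 (0.32 log units; beyond the scatter) is modest.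

Compound 4 `O=C(NC1CCN(Cc2ccc3ccccc3c2)CC1)c1ccc(Cl)cc1` differs from compound 3 by 4-chlorophenyl in place of 4-fluoro-3-methoxyphenyl on a carbonyl carbon. Among the measured compounds shown here, the steps that bear on this aryl change are a 1.5-fold lower number from compound 1 to compound 2 (0.18 log units; within the scatter), a 2.1-fold lower number from compound 1 to compound 3 (0.32 log units; beyond the scatter) and a 1.4-fold lower number from compound 2 to compound 3 (0.14 log units; within the scatter): every swap of the aryl substitution seen here has moved the number little. For compound 4 the expected step is therefore a 1.5-fold higher number from compound 3 to compound 4 (0.19 log units; within the scatter), not beyond the scatter. Compound 4 is estimated at 20 nM, range 8 nM to 50 nM.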

Compound 4, inhibition constant: 232 nM
For compound 4 the middle estimate is 12-fold (1.06 log units) below the measured one, and the stated range ends below it.
By their numbers in this assay, from the lowest: compounds 3, 2 and 1 (each within the scatter of the next, the first and the last beyond it); then compound 4.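

Among these compounds, at this position, on the carbonyl carbon, the aryl group matters more than the earlier compounds showed: 4-chlorophenyl gives an 18-fold higher number from compound 3 to compound 4 (1.25 log units; beyond the scatter), a 13-fold higher number from compound 2 to compound 4 (1.11 log units; beyond the scatter) and an 8.6-fold higher number from compound 1 to compound 4 (0.93 log units; beyond the scatter). Compound 4 is the only one of the four that carries chlorine and the only one with a single substituent on the aryl ring. Nothing at hand accounts for this loss of affinity. The compounds shown cannot separate the effect of chlorine from that of losing the second substituent. From the compounds shown here alone, how 4-fluorophenyl or unsubstituted phenyl would read at this position remains open.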